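Bromo for Chloro on a Thiazole Series

The compounds below may be only part of what the source reports. "The series", "measured", "known", "first", "only" and "open" are said of these compounds alone.

Three thiazoles have been measured in an assay on isolated protein for inhibition of Indoleamine 2,3-dioxygenase 1 (Homo sapiens), read by colorimetric assay, with stated times of 10 min and 30 min, tested at 100 uM; a higher number here means more inhibition at the concentration tested (going by the name of the read-out), a lower number less inhibition. Compound 1 `Clc1nc(-c2ccccc2)cs1` gives 0.5%. Compound 2 `Brc1nc(-c2ccccc2)cs1` gives 12%. The step of a number 11.5 percentage points higher from compound 1 to compound 2 (beyond the scatter) is described as bromo in place of chloro on an aromatic carbon. Compound 3 `S=c1[nH]c(-c2cccc(Cl)c2)cs1` gives 40%, the highest of the three numbers; the difference between its core and the core of compound 1 is not broken down here.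

Compound 4 `S=c1[nH]c(-c2cccc(Br)c2)cs1` has not yet been measured in this assay. It differs from compound 3 by bromo in place of chloro on an aromatic carbon. Among the measured compounds shown here, this is the same kind of change as the one from compound 1 to compound 2, but not the same: there the exchange sat on an aromatic carbon of a five-membered aromatic ring with 1 nitrogen and 1 sulfur, next to the ring nitrogen, next to the ring sulfur, two ring bonds from the ring atom that bears a group of 6 heavy atoms, whereas here it sits on an aromatic carbon of a six-membered aromatic ring of carbon only, meta to a group of 6 heavy atoms.

For the measured compounds named here, since the only earlier example of this kind of change, a number 11.5 percentage points higher from compound 1 to compound 2 (beyond the scatter), was modest and positive, compound 4 is expected to show a step of a number 8 percentage points higher from compound 3 to compound 4 (within the scatter), with the caveat that the place is different. Compound 4 is therefore estimated at 48%, with a likely range from 30% to 65%.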

Compound 4, a percentage reported as inhibition, at one concentration (the size of the read-out at that concentration, not a potency): 81%
Compound 4: the middle estimate sits 33 percentage points below what was measured, and the stated range ends below it.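

Bromo in place of chloro on an aromatic carbon gave a higher number both times it appears in this series, and in this assay the new exchange gave a number 41 percentage points higher from compound 3 to compound 4 (beyond the scatter). The direction of the change therefore carried over from the core of compound 1 to the core of compound 3, but its size did not: the same change on two cores in this assay, a number 11.5 percentage points higher (beyond the scatter) from compound 1 to compound 2 and a number 41 percentage points higher (beyond the scatter) from compound 3 to compound 4, 29.5 percentage points apart, beyond the scatter of two such steps This does not show a fixed gain for the exchange, nor does it show whether the larger step belongs to the core or to the place, since the two pairs differ in both, and with a single concentration the steps are sizes of the read-out and not shifts in potency.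

The compounds shown leave open how the shared core of compound 3 and compound 4 would respond to a group other than chloro or bromo in that same place, such as an amine, a methoxy group or a carboxylic acid. They also leave open whether the gain from bromo would persist with the halogen elsewhere on the carbon ring, or on a third core, so two pairs remain too few to predict the size of this exchange.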